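Chloro to methoxy on the shared core of compound 3

A few compounds are considered here, and "the series" means these few. Any claim that something is new, unique, unknown or untested is made for them only; others in the source may bear on it.

Three compounds were measured in an assay on HEK-293T cells for inhibition of diacylglycerol lipase-alpha (Homo sapiens), read by colorimetric assay; on this read-out higher numbers stand for weaker inhibition and lower numbers for stronger inhibition:
compound 1, `O=C(CCCCCCc1ccccc1)c1nc(Cl)co1`, gives 2400 nM
compound 2, `Cc1coc(C(=O)CCCCCCc2ccccc2)n1`, gives > 10000 nM, a limit of the assay
compound 3, `O=C(CCCCCCc1ccccc1)c1ncc(Cl)o1`, gives > 10000 nM, a limit of the assay

Compound 3 stands at the limit of > 10000 nM in this assay, at which 2 of the 3 values shown sit, and so has no number of its own; compound 1 is the only one of the three with a measured value. Two steps lead away from compound 1: an at least 4.1-fold higher number from compound 1 to compound 2 (0.61 log units; beyond the scatter) and an at least 4.1-fold higher number from compound 1 to compound 3 (0.61 log units; beyond the scatter). The step from compound 2 to compound 3 is a step that the two limits leave unreadable from compound 2 to compound 3. Compound 4, `COc1cnc(C(=O)CCCCCCc2ccccc2)o1`, differs from compound 3 in one place: methoxy in place of chloro on an aromatic carbon. Going by the values given here, no measured step exchanges chloro for methoxy, and the one measured change at an aromatic carbon, from compound 1 to compound 2, carried the number to a limit. Compound 3 itself sits at the limit > 10000 nM. A step that the limit leaves unreadable from compound 3 to compound 4 in this assay is therefore expected, meaning compound 4 is expected to remain weak. Compound 4 is estimated at 15000 nM, within 4000 nM to 50000 nM, most likely reported only as a limit.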

Compound 4, half-maximal inhibitory concentration: > 10000 nM
Compound 4: a limit, no number; the forecaster's own chance of this, stated with the estimate: 70%; the middle value does not contradict the limit.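

In this assay, compound 4 gives > 10000 nM, which is a limit of the assay and not a number. Going by these compounds alone, with methoxy as with chloro on the aromatic carbon next to the ring oxygen, the result stays at that limit, so this change brings no readable value at this position, and the step of an at least 4.1-fold higher number from compound 1 to compound 4 (0.61 log units; beyond the scatter) shows that compound 4, like compound 2 and compound 3, falls short of the one compound with a measured value. The steps to compound 4 from compound 2 and from compound 3 cannot be read, because both compounds of each pair sit at the same limit: the limit of > 10000 nM in this assay, at which 3 of the 4 values shown sit.

From the compounds shown here alone, how far compound 3 and compound 4 differ beyond this limit remains unknown, so neither chloro nor methoxy can be ranked at this position. Going by these compounds, it also remains open whether an amine or a nitrile on the carbon next to the ring oxygen would give a measurable value, and whether a longer chain on the carbonyl carbon would change the value of compound 1.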